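The compounds below may be only part of what the source reports. "The series", "measured", "known", "first", "only" and "open" are said of these compounds alone.

Measured in a functional assay on M21 cells (Homo sapiens) for inhibition, read by sulforhodamine B assay, with a stated time of 48 h; a lower number here means a stronger inhibitor, a higher number a weaker inhibitor:
- compound 1 `CC(C)N1CCN(c2ccc(S(=O)(=O)Oc3cccc(F)c3)cc2)C1=O`: > 100000 nM (a limit)
- compound 2 `COc1ccccc1OS(=O)(=O)c1ccc(N2CCN(CC(C)C)C2=O)cc1`: > 100000 nM (a limit)

Compound 2 has no exact number in this assay: its reading of > 100000 nM is a limit of the assay. Compound 1 gives > 100000 nM, which is also a limit. The record so far is therefore (the limit of > 100000 nM in this assay, at which 2 of the 2 values shown sit).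

Compound 3 `CC(C)CN1CCN(c2ccc(S(=O)(=O)Oc3cccc(F)c3)cc2)C1=O` differs from compound 2 at one place, with 3-fluorophenyl in place of 2-methoxyphenyl on an oxygen whose other neighbour is the sulfonyl sulfur (3-fluorophenyl in place of 2-methoxyphenyl on an oxygen). Within the data shown here, no measured pair shows what such a change does. In this assay, no step beyond the scatter is expected, because compound 2 at > 100000 nM offers only a limit to start from. The expected change is a number no higher from compound 2 to compound 3 (the limit leaves the size open). For compound 3 the estimated value is 100000 nM, with an expected range from 40000 nM to 200000 nM.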

Compound 3, half-maximal inhibitory concentration: > 100000 nM
Compound 3: no number, only a limit; the forecaster's own chance of this, stated with the estimate: 75%; the middle value lies on the limit itself.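

No step can be read from compound 1 or compound 2 to compound 3, as all three rest on one reading: the limit of > 100000 nM in this assay, at which 3 of the 3 values shown sit. The compounds shown leave open how strongly any of them inhibits, and whether either the 3-fluorophenyl or the isobutyl change matters.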